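This account rests on a few compounds, and the source may have more. Where it says the series, first, only, none or still open, it means among the compounds named here.

In an ADME assay on PBMC cells (Homo sapiens) for cytotoxicity, with a stated time of 5 days (on this read-out higher numbers stand for weaker inhibition and lower numbers for stronger inhibition), compound 1 (`COc1nc(NC2CC2)c2ncn([C@H]3C[C@H](N=[N+]=[N-])[C@@H](CO)O3)c2n1`) gives > 100000 nM, which is a limit of the assay and not a number. Compound 2 (`C=CCNc1ncnc2c1ncn2[C@H]1C[C@H](N=[N+]=[N-])[C@@H](CO)O1`) gives 51100 nM. Compound 3 (`C=CCNc1nc(N)nc2c1ncn2[C@H]1C[C@H](N=[N+]=[N-])[C@@H](CO)O1`) gives > 100000 nM, again a limit. The small set is therefore marked by the limit of > 100000 nM in this assay, at which 2 of the 3 values shown sit.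

Compound 4 (`[N-]=[N+]=N[C@H]1C[C@H](n2cnc3c(NC4CC4)nc(Cl)nc32)O[C@@H]1CO`) has not yet been measured, and it differs from compound 1 as follows: chloro in place of methoxy on an aromatic carbon. This puts chloro in place of methoxy on an aromatic carbon. Among the measured compounds shown here, no measured step makes this exchange. For the measured compounds named here, the one measured step, an at least 1.9-fold higher number from compound 2 to compound 3 (0.29 log units; that floor lies within the scatter), is a different change, amino in place of hydrogen on an aromatic carbon, so it offers only weak guidance.

Compound 2 at 51100 nM shows that a relative can give a number in this assay, so a modest move to a lower number is expected, possibly no larger than the scatter. For compound 4, the expected value is 70000 nM, with an estimated range of 25000 nM to 100000 nM. The estimate means an expected at least 1.4-fold lower number from compound 1 to compound 4 (0.15 log units; that floor lies within the scatter).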

Compound 4, half-maximal inhibitory concentration: 35300 nM
The estimate for compound 4 lay 2.0-fold (0.30 log units) above the measured number; measured number inside the range.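

In this assay, chloro in place of methoxy on the aromatic carbon between two ring nitrogen atoms gives an at least 2.8-fold lower number from compound 1 to compound 4 (0.45 log units; beyond the scatter). This is the first step shown that lies beyond the scatter, and it shows that, with the cyclopropylamino group held constant, the group at this position can move the read-out off the limit. The step gives only a minimum size and not an exact one, because compound 1 rests on a limit, not a number: the limit of > 100000 nM in this assay, at which 2 of the 4 values shown sit.

The compounds shown leave open how fluoro, bromo or a longer alkoxy chain would read at this position. They also leave open whether chloro in place of methoxy would give a similar step with allylamino in place of the cyclopropylamino group.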